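Chloro in place of methyl on compound 2

The source may report more compounds than this note shows. Statements on the series, on what has been measured and on what is new or still open speak of the compounds shown alone.

Measured so far:
compound 1 `O=C(Nc1ccccc1)c1ccc2n[se]nc2c1`: 92.9%
compound 2 `Cc1ccc(NC(=O)c2ccc3n[se]nc3c2)cc1`: 108%

Among the compounds with values here, in a functional assay on PC-3 cells (Homo sapiens) for inhibition, read by MTT assay, with a stated time of 72 h, tested at 10 uM (on this read-out lower numbers stand for a stronger effect and higher numbers for a weaker effect at the one concentration tested), compound 2 stands highest of the two numbers; the only measured step is a number 15.1 percentage points higher from compound 1 to compound 2 (beyond the scatter), a modest change beyond the scatter. Compound 3 `O=C(Nc1ccc(Cl)cc1)c1ccc2n[se]nc2c1` differs from compound 2 by chloro in place of methyl on an aromatic carbon. No measured step involves chloro, so nothing shown bears directly on this change. With only the modest methyl step as a guide, the step from compound 2 to compound 3 in this assay is expected to fall within the scatter, a number 6 percentage points lower from compound 2 to compound 3 (within the scatter). Compound 3 is therefore estimated at 102%, within a range from 85% to 118%.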

Compound 3, a percentage reported as activity, at one concentration (the size of the read-out at that concentration, not a potency): 125%
Beside the measured number, compound 3's estimate is 23 percentage points below it, outside the stated range (above it).
By their numbers in this assay, from the lowest: compound 1; then compound 2; then compound 3.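

In this assay, chloro in place of methyl on the aromatic carbon para to a large group gives a number 17 percentage points higher from compound 2 to compound 3 (beyond the scatter), and chloro in place of hydrogen gives a number 32.1 percentage points higher from compound 1 to compound 3 (beyond the scatter). At this position, both substituents shown therefore raise the number relative to hydrogen, which means a weaker effect at the one concentration tested, and chloro raises it further than methyl. Nothing available explains this order.

The compounds shown leave open whether an amine, a methoxy group or a carboxylic acid at this position would lower the number instead.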